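Swapping trifluoromethyl for fluoro in a small cytotoxicity series

The source may report more compounds than this note shows. Statements on the series, on what has been measured and on what is new or still open speak of the compounds shown alone.

Compound 1 `O=C1OC[C@H](Cc2ccccc2)[C@H]1Cc1ccccc1C(F)(F)F` and compound 3 `O=C1OC[C@H](Cc2ccccc2)[C@H]1Cc1ccc(C(F)(F)F)cc1` each carry a trifluoromethyl group, while compound 2 `O=C1OC[C@H](Cc2ccccc2)[C@H]1Cc1ccccc1F` carries fluoro instead. In a functional assay on HL-60 cells (Homo sapiens) for cytotoxicity, read by WST assay, with a stated time of 48 h (on this read-out lower numbers stand for an effect already at smaller amounts and higher numbers for an effect only at larger amounts of compound), compound 1 gives 37000 nM, compound 2 gives 72000 nM, and compound 3 gives 22000 nM. The difference between the cores of compound 1 and compound 3 is not broken down here. The change from compound 1 to compound 2 is fluoro in place of trifluoromethyl on an aromatic carbon and brought a 1.9-fold higher number from compound 1 to compound 2 (0.29 log units; within the scatter). Compound 4 `O=C1OC[C@H](Cc2ccccc2)[C@H]1Cc1ccc(F)cc1`, not yet measured, differs from compound 3 by fluoro in place of trifluoromethyl on an aromatic carbon; this is the same kind of change, though here the place is para to a large group rather than ortho to a large group. Because a 1.9-fold higher number from compound 1 to compound 2 (0.29 log units; within the scatter) was seen, a step of similar size is expected: a 1.9-fold higher number from compound 3 to compound 4 (0.28 log units; within the scatter). Compound 4 is therefore expected to give about 42000 nM in this assay, most likely between 20000 nM and 90000 nM.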

Compound 4, half-maximal effective concentration: 57000 nM
Compound 4: the middle estimate sits 1.4-fold (0.13 log units) below what was measured; the measured number falls inside the stated range.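

In this assay, fluoro in place of trifluoromethyl on an aromatic carbon gave a 2.6-fold higher number from compound 3 to compound 4 (0.41 log units; beyond the scatter), and the step on this core matches the earlier one on the core of compound 1: the same change on two cores in this assay, a 1.9-fold higher number (0.29 log units; within the scatter) from compound 1 to compound 2 and a 2.6-fold higher number (0.41 log units; beyond the scatter) from compound 3 to compound 4, 1.3-fold (0.12 log units) apart, within the scatter of two such steps. With the fluoro kept and its place on the ring changed, the 4-fluorophenyl in place of 2-fluorophenyl step gave a 1.3-fold lower number from compound 2 to compound 4 (0.10 log units; within the scatter), so these two compounds cannot be told apart. The change therefore carried over between these two cores, but two pairs cannot show that it would do so on other cores, and they do not explain why the number rises.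

From the compounds shown here alone, it remains open how other groups at this place on the aromatic ring, such as a nitrile, an amine or a carboxylic acid, would compare. The compounds shown also leave open what a plain hydrogen there would give.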